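The compounds below may be only part of what the source reports. "The series", "measured", "known", "first", "only" and "open" are said of these compounds alone.

Measured in an ADME assay on MT4 cells (Homo sapiens) for activation, read by MTT assay; on this read-out lower numbers stand for higher toxicity in this test and higher numbers for lower toxicity in this test:
- Compound 1 `CC(C)Sc1nc(Cc2c(F)cccc2Cl)cc(=O)[nH]1`: > 80000 nM, a limit
- Compound 2 `CCCSc1nc(Cc2c(F)cccc2Cl)c(C)c(=O)[nH]1`: > 76000 nM, a limit
- Compound 3 `CC(C)Sc1nc(C(C)c2c(F)cccc2Cl)cc(=O)[nH]1`: > 75000 nM, a limit

Compound 3 gives no number, only the limit > 75000 nM. The other two compounds likewise reach only limits, so no measured value fixes where this series stands.

Compound 4 `CCC(C)Sc1nc(C(C)c2c(F)cccc2Cl)cc(=O)[nH]1` is made from compound 3 by a single change, (methyl in place of hydrogen on a saturated chain carbon, two bonds along the chain from a sulfur), which turns isopropylsulfanyl into (sec-butyl)sulfanyl.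

Among the measured compounds shown here, one measured step bears on it, a methyl in place of hydrogen at a different place: a step that the two limits leave unreadable from compound 1 to compound 3. That step has no readable size, so it offers no measure of what an added methyl does here. With nothing readable to go on, no step beyond the scatter is expected in this assay, in either direction, and a further limit is the likeliest report.

The expected step is an at least 1.0-fold lower number from compound 3 to compound 4 (0.02 log units; that floor lies within the scatter).

For compound 4 the estimate is 70000 nM, with an expected range from 25000 nM to 100000 nM.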

Compound 4, half-maximal cytotoxic concentration: > 73000 nM
Compound 4: only a limit was reported; the forecaster's own chance of this, stated with the estimate: 70%; middle value at least 1.0-fold (0.01 log units) away from the limit.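

Compound 3 and compound 4 both give only limits in this assay, so no step can be read between them. The compounds shown leave open how far the half-maximal cytotoxic concentrations lie beyond these limits, and whether the added methyl changes them at all.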